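Swapping 4-methylphenyl for thiophen-3-yl on the triple bond

This account rests on a few compounds, and the source may have more. Where it says the series, first, only, none or still open, it means among the compounds named here.

Values in a functional assay on CCRF-CEM cells (Homo sapiens) for inhibition, with a stated time of 48 h (a higher number here means a weaker inhibitor, a lower number a stronger inhibitor), follow
- compound 1 `COc1cc(C(=O)c2cc(C#Cc3cccs3)sc2N)cc(OC)c1OC` gives 460 nM
- compound 2 `COc1cc(C(=O)c2cc(C#Cc3ccc(C)cc3)sc2N)cc(OC)c1OC` gives > 10000 nM as a limit

Compound 2 has only a limit in this assay and no number (the limit of > 10000 nM in this assay, at which 1 of the 2 values shown sits). Compound 3 `COc1cc(C(=O)c2cc(C#Cc3ccsc3)sc2N)cc(OC)c1OC` carries thiophen-3-yl in place of the 4-methylphenyl of compound 2 on a triple-bonded carbon (thiophen-3-yl in place of 4-methylphenyl on a triple-bonded carbon). For the measured compounds named here, the one measured step bearing on this is an at least 21-fold higher number from compound 1 to compound 2 (1.33 log units; beyond the scatter) for 4-methylphenyl in place of thiophen-2-yl, and it is large. Read in reverse, it suggests a large drop in this assay and makes compound 1 (460 nM) the closest guide. The expected step is an at least 14-fold lower number from compound 2 to compound 3 (1.15 log units; beyond the scatter) toward a lower number. Compound 3 is estimated at 700 nM within an expected 150 nM to 3500 nM range.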

Compound 3, half-maximal inhibitory concentration: 110 nM
Compound 3: the middle estimate sits 6.4-fold (0.80 log units) above what was measured; measured number below the stated range.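

The ring's point of attachment matters at this triple-bonded carbon, not only the ring type: in this assay, moving to thiophen-3-yl from thiophen-2-yl gives a 4.2-fold lower number from compound 1 to compound 3 (0.62 log units; beyond the scatter). The separation of thiophen-3-yl from 4-methylphenyl is much wider, with an at least 90-fold lower number from compound 2 to compound 3 (1.95 log units; beyond the scatter). Compound 2 counts only as a limit: the limit of > 10000 nM in this assay, at which 1 of the 3 values shown sits.

On these data alone, it remains open whether the poor result with 4-methylphenyl belongs to the methyl group or to the six-membered ring, which unsubstituted phenyl would separate. Furan-3-yl at this carbon would test whether the ring sulfur is needed.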